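A few compounds are considered here, and "the series" means these few. Any claim that something is new, unique, unknown or untested is made for them only; others in the source may bear on it.

Going by the values given here, in a functional assay on HT-29 cells (Homo sapiens) for antiproliferative activity, read by MTT assay, with a stated time of 96 h (on this read-out higher numbers stand for weaker inhibition and lower numbers for stronger inhibition), compound 2 `O=C1NN(c2ccc([N+](=O)[O-])cc2)C(=O)C2(CSC3=C2C(=O)c2ncccc2C3=O)N1` gives 1010 nM, the highest of the three numbers so far, while compound 1 `O=C1C2=C(C(=O)c3ncccc31)C1(CS2)NC(=O)N(c2ccc(Cl)cc2)C1=O` gives 2 nM and compound 3 `CCc1ccc(N2C(=O)NC3(CSC4=C3C(=O)c3ncccc3C4=O)C2=O)cc1` gives 1 nM, both lower by far more than the scatter. Compound 4 `O=C1NN(c2ccccc2)C(=O)C2(CSC3=C2C(=O)c2ncccc2C3=O)N1` keeps the core of compound 2 but has hydrogen in place of nitro on an aromatic carbon, para to a large group: hydrogen in place of nitro on an aromatic carbon. Among the compounds with values here, the only measured swap of one aromatic substituent for another, a 2.0-fold lower number from compound 1 to compound 3 (0.30 log units; within the scatter), sits on a different core, and no measured step removes a nitro. A step beyond the scatter is therefore not expected in this assay, in either direction. The estimated change is a 1.4-fold lower number from compound 2 to compound 4 (0.16 log units; within the scatter). For compound 4 the expected value is 700 nM, with an estimated range of 100 nM to 3000 nM.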

Compound 4, half-maximal inhibitory concentration: 550 nM
For compound 4 the middle estimate is 1.3-fold (0.10 log units) above the measured one; the measured number falls inside the stated range.
By their numbers in this assay, from the lowest: compounds 3 and 1 (each within the scatter of the next); then compounds 4 and 2 (each within the scatter of the next).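

In this assay, going from 4-nitrophenyl to phenyl gives a 1.8-fold lower number from compound 2 to compound 4 (0.26 log units; within the scatter). Going by these compounds alone, this is the first measured step that removes a nitro, and it shows that on this core the position can lose that group without a step beyond the scatter. No measurement shown explains why the nitro makes so little difference here. Going by these compounds, whether an amine, a carboxylic acid or a longer chain at this position would move the number stays open. So does whether the chloro or ethyl of compound 1 and compound 3 would give low numbers on this core.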